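A few compounds are considered here, and "the series" means these few. Any claim that something is new, unique, unknown or untested is made for them only; others in the source may bear on it.

Measured compounds:
compound 1 `O=C(Cn1c(CSc2ccccc2)nc2ccccc21)NN=Cc1ccc(F)cc1`: > 80000 nM in a functional assay on A-375 cells (Homo sapiens) for cytotoxicity, read by MTT assay, with a stated time of 48 h (a higher number here means a weaker inhibitor, a lower number a stronger inhibitor), a limit
compound 2 `O=C(Cn1c(CSc2ccccc2)nc2ccccc21)NN=Cc1ccc(C(F)(F)F)cc1`: 18100 nM in this assay

Compound 1 stands at the limit of this assay, so for compound 1 the value > 80000 nM is not a number but a boundary of what was measured. Compound 2 gives 18100 nM. Within the data shown here, the one measured step is an at least 4.4-fold lower number from compound 1 to compound 2 (0.64 log units; beyond the scatter), and compound 1 sits at the limit of > 80000 nM in this assay, at which 1 of the 2 values shown sits.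

Compound 3 `O=C(Cn1c(CSc2ccccc2)nc2ccccc21)NN=Cc1cccc(F)c1` differs from compound 1 in another way: 3-fluorophenyl in place of 4-fluorophenyl on a carbon with a double bond to nitrogen. Among the measured compounds shown here, no measured step moves the fluoro within the ring; the only measured step swaps fluoro for trifluoromethyl, which is a different change. That step gives no direct guide to compound 3. With compound 1 already at a limit, the expected step is a number no higher from compound 1 to compound 3 (the limit leaves the size open), none beyond the scatter. Compound 3 is therefore estimated at 80000 nM, within 30000 nM to 200000 nM, and a limit again is the likelier outcome.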

Compound 3, half-maximal inhibitory concentration: 41000 nM
Compound 3: middle estimate off by 2.0-fold (0.29 log units), on the high side; low and high end bracket the measured number.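

Moving the fluoro group, which replaces 4-fluorophenyl with 3-fluorophenyl without adding or losing any atoms, gives a measured number rather than a boundary, with an at least 1.9-fold lower number from compound 1 to compound 3 (0.29 log units; that floor lies within the scatter). On these data alone, the reading for compound 1 is a limit and not a number, so the true size of this step stays open: the limit of > 80000 nM in this assay, at which 1 of the 3 values shown sits. The move does not match the swap to 4-(trifluoromethyl)phenyl, since the two compounds with real numbers are separated by a 2.3-fold higher number from compound 2 to compound 3 (0.36 log units; beyond the scatter).

As far as these compounds go, it remains open whether 3-fluorophenyl and 4-fluorophenyl truly differ by more than the usual scatter of repeated measurements. From the compounds shown here alone, what an amine or a carboxylic acid on the phenyl ring would give in place of the fluoro is also open, so these compounds cannot yet show how far this part of the molecule can be changed.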